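Swapping chloro for methyl on a shared aromatic core

This account rests on a few compounds, and the source may have more. Where it says the series, first, only, none or still open, it means among the compounds named here.

Compound 1, `CC(=O)c1c(O)ccc2oc(-c3ccccc3C)nc12`, in a functional assay on HeLa cells (Homo sapiens) for cytotoxicity, read by MTT assay, with a stated time of 48 h (on this read-out lower numbers stand for stronger inhibition and higher numbers for weaker inhibition), gives 19200 nM.
Compound 2, `O=Cc1c(O)ccc2oc(-c3ccccc3Cl)nc12`, in this assay gives 14100 nM.

Compound 2 has the lowest of the two numbers, yet compound 1 stands within the scatter of it, so no order between them can be claimed. Compound 3, `Cc1ccccc1-c1nc2c(C=O)c(O)ccc2o1`, carries the change (methyl in place of chloro on an aromatic carbon), placed ortho to a large group. Within the data shown here, no measured pair shows this change alone. In this assay a step from compound 2 to compound 3 of no more than the usual scatter is expected, in either direction. The estimate for compound 3 is 16000 nM, expected between 7000 nM and 36000 nM. That estimate means an expected step of a 1.1-fold higher number from compound 2 to compound 3 (0.05 log units; within the scatter).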

Compound 3, half-maximal inhibitory concentration: 15400 nM
Estimate against measurement, compound 3: 1.0-fold (0.02 log units) above, within the range that was stated.
By their numbers in this assay, from the lowest: compounds 2, 3 and 1 (each within the scatter of the next).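

In this assay, among these compounds, methyl in place of chloro on this aromatic carbon, ortho to a large group, gives a 1.1-fold higher number from compound 2 to compound 3 (0.04 log units; within the scatter) and is the first direct reading of this change. Hydrogen in place of methyl on the carbonyl carbon gives a 1.2-fold lower number from compound 1 to compound 3 (0.10 log units; within the scatter) as its step, so neither single change separates these compounds. No measurement at hand offers an explanation for these small steps. The compounds shown leave open whether an amine, a carboxylic acid or a longer chain on this aromatic carbon would give a step beyond the scatter.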